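Tyrosol and hydroxytyrosol esters: fibroblast toxicity notes

The compounds below may be only part of what the source reports. "The series", "measured", "known", "first", "only" and "open" are said of these compounds alone.

The series holds four phenolic esters. Compound 2 `CC(=O)OCCc1ccc(O)cc1` and compound 3 `CCCCCCCC(=O)OCCc1ccc(O)cc1` share one core; compound 1 `CC(=O)OCCc1ccc(O)c(O)c1` and compound 4 `CCCCCCCC(=O)OCCc1ccc(O)c(O)c1` carry one more hydroxy on that core. In a toxicity assay on MRC5 cells (Homo sapiens) for inhibition, read by MTT assay, with a stated time of 72 h (a higher number here means a weaker inhibitor, a lower number a stronger inhibitor), compound 2 gives 114000 nM. In this assay compound 3 gives 133000 nM. The core of compound 3 differs from that of compound 2 by hexyl in place of hydrogen on a saturated chain carbon bound to a carbonyl carbon, and this brings a 1.2-fold higher number from compound 2 to compound 3 (0.07 log units; within the scatter). In this assay compound 1 reaches only > 50000 nM, which is a limit of the measurement and not a number. The change from compound 2 to compound 1, (hydroxy in place of hydrogen on an aromatic carbon), therefore leaves a step that the limit leaves unreadable from compound 2 to compound 1 because the limit of > 50000 nM in this assay, at which 1 of the 3 values shown sits, cuts the reading off. Compound 4 carries the same kind of change on compound 3, (hydroxy in place of hydrogen on an aromatic carbon); the two places differ only in being meta to a large group rather than meta to a group of 6 heavy atoms. Since the longer chain on compound 3 gave a 1.2-fold higher number from compound 2 to compound 3 (0.07 log units; within the scatter), and the added hydroxy on compound 2 gave no readable number, the added hydroxy on compound 3 is expected to land near the same limit region. The step expected is a 2.2-fold lower number from compound 3 to compound 4 (0.35 log units; beyond the scatter), set beside a step that the limit leaves unreadable from compound 2 to compound 1. Compound 4 is therefore estimated at 60000 nM, with a likely range from 20000 nM to 150000 nM, and a fair chance that only a limit is reported.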

Compound 4, half-maximal inhibitory concentration: 104000 nM
The estimate for compound 4 lay 1.7-fold (0.24 log units) below the measured number, and the stated range covers the measured number.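

In this assay, going by these compounds alone, hydroxy in place of hydrogen on an aromatic carbon of compound 3 brings a 1.3-fold lower number from compound 3 to compound 4 (0.11 log units; within the scatter), so the one readable case of this change shows no step that can be told apart from repeat measurement. The same change made on compound 2 and the hexyl change made on compound 1 both give steps that cannot be read, because compound 1 carries a limit and not a number: the limit of > 50000 nM in this assay, at which 1 of the 4 values shown sits. The series thus gives one reading of the hydroxy change, on the core of compound 3, and it does not show whether that reading carries over to the core of compound 2, so neither a match nor a difference between the two cores can be claimed.

The compounds shown leave open how the numbers in this assay would respond to a chain longer than hexyl, or to an amine or a carboxylic acid in place of hexyl. They also leave open whether the hydroxy change would stay within the scatter on such compounds, as it does on compound 3.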